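Thiourea series: aryl swap on the saturated ring carbon

The source may hold more compounds than are shown below. What is called first, only, known or untested is meant among the compounds shown, and "the series" means these compounds.

Compound 1 `COc1cc(/C=C/C(=O)C2=C(/C=C/c3ccc(O)c(OC)c3)NC(=O)NC2c2ccc(N(C)C)cc2)ccc1O` gives 48% in a functional assay, with a stated time of 20 min, tested at 20 uM; on this read-out higher numbers stand for a stronger effect at the one concentration tested and lower numbers for a weaker effect. Compound 2 `COc1cc(/C=C/C(=O)C2=C(/C=C/c3ccc(O)c(OC)c3)NC(=O)NC2c2c(Cl)cccc2Cl)ccc1O`, which carries 2,6-dichlorophenyl in place of 4-(dimethylamino)phenyl on a saturated ring carbon, gives 31.9%; the step is a number 16.1 percentage points lower from compound 1 to compound 2 (beyond the scatter). Among the measured compounds shown here, compound 3 `COc1cc(/C=C/C(=O)C2=C(/C=C/c3ccc(O)c(OC)c3)NC(=S)NC2c2ccc(N(C)C)cc2)ccc1O` gives 83%, the highest of the three numbers measured so far; how its core differs from that of compound 1 is not broken down here. Compound 4 `COc1cc(/C=C/C(=O)C2=C(/C=C/c3ccc(O)c(OC)c3)NC(=S)NC2c2c(Cl)cccc2Cl)ccc1O` has not yet been measured; it carries 2,6-dichlorophenyl in place of 4-(dimethylamino)phenyl on a saturated ring carbon, the same change as that between compound 1 and compound 2, at the same place. For the measured compounds named here, the step that is expected is a number 18 percentage points lower from compound 3 to compound 4 (beyond the scatter), resting on a number 16.1 percentage points lower from compound 1 to compound 2 (beyond the scatter), although only that one pair shows this change and the starting number is higher, so the expectation is loose. Compound 4 is estimated at 65%, most likely between 48% and 80%.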

Compound 4, a percentage reported as activity, at one concentration (the size of the read-out at that concentration, not a potency): 43.2%
Compound 4: middle estimate off by 21.8 percentage points, on the high side; measured number outside the range, below it.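

In this assay, the swap of 4-(dimethylamino)phenyl for 2,6-dichlorophenyl on the saturated ring carbon gives a number 39.8 percentage points lower from compound 3 to compound 4 (beyond the scatter), the same direction as on the core of compound 1 but a larger step. The direction carries over between the two cores, while the size does not: the same change on two cores in this assay, a number 16.1 percentage points lower (beyond the scatter) from compound 1 to compound 2 and a number 39.8 percentage points lower (beyond the scatter) from compound 3 to compound 4, 23.7 percentage points apart, beyond the scatter of two such steps

A step read on one core therefore gave the sign of this change on the other but not its size, and these two pairs show nothing about why the sizes differ or about any other core.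

The compounds shown leave open how the two cores compare with other groups on the saturated ring carbon, such as an unsubstituted phenyl or a 4-chlorophenyl. Going by these compounds, whether the larger step on the core of compound 3 would recur with those groups also remains open.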